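Dihydroxyphenyl in place of dichlorophenyl on an adenosine scaffold

This account rests on a few compounds, and the source may have more. Where it says the series, first, only, none or still open, it means among the compounds named here.

Compound 1, `OC[C@H]1O[C@@H](n2cnc3c(NCc4ccc(Cl)cc4)ncnc32)[C@H](O)[C@@H]1O`: > 166000 nM in a functional assay on G-361 cells (Homo sapiens) for antiproliferative activity, with a stated time of 72 h (on this read-out lower numbers stand for stronger inhibition and higher numbers for weaker inhibition), a limit of the assay.
Compound 2, `COc1cccc(CNc2ncnc3c2ncn3[C@@H]2O[C@H](CO)[C@@H](O)[C@H]2O)c1`: "not determined" (no result reported) in this assay.
Compound 3, `OC[C@H]1O[C@@H](n2cnc3c(NCc4ccc(Cl)cc4Cl)ncnc32)[C@H](O)[C@@H]1O`: 128000 nM in this assay.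

Compound 3 holds the only number shown; compound 1 sits at the limit (the limit of > 166000 nM in this assay, at which 1 of the 3 values shown sits), and compound 2 has no result. Among the compounds with values here, the one measured step, an at least 1.2-fold lower number from compound 1 to compound 3 (0.11 log units; that floor lies within the scatter), stays within the scatter. Compound 4, `OC[C@H]1O[C@@H](n2cnc3c(NCc4cccc(O)c4O)ncnc32)[C@H](O)[C@@H]1O`, differs from compound 3 by 2,3-dihydroxyphenyl in place of 2,4-dichlorophenyl on a saturated chain carbon bound to a nitrogen on an aromatic ring. Within the data shown here, no measured step covers this exchange, so the expectation rests on compound 3 alone, and a step of a 1.0-fold higher number from compound 3 to compound 4 (0.01 log units; within the scatter) is expected, none beyond the scatter. Compound 4 is thus estimated at 130000 nM, with a range from 40000 nM to 400000 nM.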

Compound 4, half-maximal inhibitory concentration: 16900 nM
Beside the measured number, compound 4's estimate is 7.7-fold (0.89 log units) above it; the whole stated range lies above it.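

In this assay the group on a saturated chain carbon bound to a nitrogen on an aromatic ring now moves the read-out beyond the scatter, which the earlier chloro step did not: 2,3-dihydroxyphenyl in place of 2,4-dichlorophenyl gives a 7.6-fold lower number from compound 3 to compound 4 (0.88 log units; beyond the scatter) here. In place of 4-chlorophenyl it gives an at least 9.8-fold lower number from compound 1 to compound 4 (0.99 log units; beyond the scatter) as a floor only. The value of compound 1 is a limit of the assay: the limit of > 166000 nM in this assay, at which 1 of the 4 values shown sits.

As far as these compounds go, whether one hydroxyl alone would give this gain stays open. So does whether an amino group could take its place.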